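This account rests on a few compounds, and the source may have more. Where it says the series, first, only, none or still open, it means among the compounds named here.

Measured so far in a functional assay on Calu-1 cells (Homo sapiens) for cytotoxicity, read by resazurin assay, with a stated time of 72 h; on this read-out higher numbers stand for weaker inhibition and lower numbers for stronger inhibition:

Compound 1 `O=C(/C=C/c1ccc(OCCCCO[N+](=O)[O-])c(O)c1)OCCCCO[N+](=O)[O-]`: compound 1 gives > 50000 nM, a limit of the assay.
Compound 2 `O=C(/C=C/c1ccc(OCCCCCCO[N+](=O)[O-])c(O)c1)OCCCCCCO[N+](=O)[O-]`: compound 2 gives > 50000 nM, a limit of the assay.
Compound 3 `COc1cc(/C=C/C(=O)OCCCCO[N+](=O)[O-])ccc1OCCCCO[N+](=O)[O-]`: compound 3 gives > 50000 nM, a limit of the assay.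

All three values sit at the limit of > 50000 nM in this assay, at which 3 of the 3 values shown sit, so no number is read for any of them. Compound 1 and compound 3 differ by methyl in place of hydrogen on an oxygen on an aromatic ring; the step that the two limits leave unreadable from compound 1 to compound 3 is not readable, since both ends are limits. The difference between the cores of compound 1 and compound 2 is not broken down here.

Compound 4 `COc1cc(/C=C/C(=O)OCCCCCCO[N+](=O)[O-])ccc1OCCCCCCO[N+](=O)[O-]` is not yet measured. It differs from compound 2 by methyl in place of hydrogen on an oxygen on an aromatic ring, the same change as from compound 1 to compound 3. Given that compound 3 stays at > 50000 nM, compound 4 is expected to stay at the limit as well, an expected step that the limit leaves unreadable from compound 2 to compound 4. The estimate for compound 4 in this assay is 100000 nM.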

Compound 4, half-maximal inhibitory concentration: 27800 nM
Compound 4: middle estimate off by 3.6-fold (0.56 log units), on the high side, and the stated range ends above it.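

In this assay hydroxy to methoxy on the core of compound 2 gives an at least 1.7-fold lower number from compound 2 to compound 4 (0.25 log units; that floor lies within the scatter) and so sets only a floor on the size of the step, a floor that stays within the scatter.
The same change on the core of compound 1 cannot be read, since compound 1 and compound 3 both stand at a limit: the limit of > 50000 nM in this assay, at which 3 of the 4 values shown sit.
Carrying the change from one core to the other is therefore not shown, with a measured number only for compound 4 at 27800 nM on that one core.

Open, on these data alone, is what a longer chain on the core of compound 4 would give in this assay and what a carboxylic acid in place of the methoxy group would give.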